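The source may report more compounds than this note shows. Statements on the series, on what has been measured and on what is new or still open speak of the compounds shown alone.

In a functional assay on HO8910 cells (Homo sapiens) for inhibition, read by MTT assay, with a stated time of 24 h, tested at 10 ug/mL (on this read-out higher numbers stand for more inhibition of growth at the one concentration tested and lower numbers for less inhibition of growth), compound 1 (`CC(=O)SCCC(CCCCC(=O)O)SC(C)=O`) gives 1.61% and so stands at the low end of the scale. Compound 2 (`O=C(CCCCC1CCSS1)Nc1ccc(OC(F)(F)F)cc1`) gives 8.57% on the same read-out. These two numbers lie within the scatter of each other, so no order can be drawn between them. Compound 3 (`O=C(CCCCC(S)CCS)Nc1ccc([N+](=O)[O-])c(C(F)(F)F)c1`) is reported as "not active" (no number reported) with no number attached, and it cannot be placed against the other two.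

The step to follow starts from compound 1. Compound 4 (`CC(=O)SCCC(CCCCC(=O)Nc1ccc(Cl)cc1)SC(C)=O`), not yet measured, has (4-chlorophenyl)amino in place of hydroxy on a carbonyl carbon and keeps the rest of the core of compound 1. Within the data shown here, no measured pair isolates this change, so the expectation rests on indirect evidence. Compound 2 at 8.57% and compound 3 at "not active" (no number reported) also carry an aromatic ring on that carbonyl through nitrogen, and neither reading points to a large gain in this assay for such a group. A small upward shift, or none beyond the scatter, is therefore expected, and the estimated step of a number 9.4 percentage points higher from compound 1 to compound 4 (within the scatter) remains modest. For compound 4 the estimated reading is 11% with an expected range from 1% to 32% at the one concentration tested.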

Compound 4, percent growth inhibition at one concentration: 1.47%
For compound 4 the middle estimate is 9.5 percentage points above the measured one; the range from low to high includes it.
By their numbers in this assay, from the lowest: compounds 4, 1 and 2 (each within the scatter of the next).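

Among these compounds, the step of a number 0.1 percentage points lower from compound 1 to compound 4 (within the scatter) in this assay is the first measured pair that isolates one change at this position, and it replaces inference from compounds that differ in more than one place. On a carbonyl carbon whose other neighbour is a saturated chain carbon, (4-chlorophenyl)amino in place of hydroxy adds one six-membered aromatic ring and removes the free acid, yet no difference can be read between the two compounds on this read-out, with both at the low end of the scale. The compounds shown offer no measured evidence that could account for this outcome.

Open, from the compounds shown here alone, is whether another group on the same carbonyl carbon, such as a methyl ester, a morpholine amide or a benzylamino group, would read apart from compound 1 beyond the usual scatter. Going by these compounds, with only one aryl substituent tested on the shared core, it also remains open whether a methoxy group or a nitrile in place of the chlorine in compound 4 would lift the reading from this low range.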